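Trading the Naphthalene Ether for a Trifluorophenyl Ether

The compounds below may be only part of what the source reports. "The series", "measured", "known", "first", "only" and "open" are said of these compounds alone.

Compound 2 `CC(C)[C@H](NC(=O)COc1cccc2ccccc12)C(=O)N[C@@H](CC(=O)O)C(=O)COc1cccc2ccccc12` belongs to a set of three compounds sharing one core and tested in a functional assay on Jurkat cells (Homo sapiens); on this read-out higher numbers stand for weaker inhibition and lower numbers for stronger inhibition. In this assay compound 2 reached only > 100000 nM, which is a limit of the measurement rather than a number. Compound 1 `CC(C)[C@H](NC(=O)COc1cccc2ccccc12)C(=O)N[C@@H](CC(=O)O)C(=O)COC(=O)c1c(Cl)cccc1Cl` gives 10600 nM in this assay. Compound 3 `CC(C)[C@H](NC(=O)COc1cccc2ccccc12)C(=O)N[C@@H](CC(=O)O)C(=O)COc1ccc(C#N)cc1` also stopped at > 100000 nM in this assay, again a limit. Two of the three values thus sit at the limit of > 100000 nM in this assay, at which 2 of the 3 values shown sit. Both changes away from compound 1 weakened inhibition: an at least 9.4-fold higher number from compound 1 to compound 2 (0.97 log units; beyond the scatter) and an at least 9.4-fold higher number from compound 1 to compound 3 (0.97 log units; beyond the scatter). Between the two ethers, a step that the two limits leave unreadable from compound 2 to compound 3.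

Compound 4 `CC(C)[C@H](NC(=O)COc1cccc2ccccc12)C(=O)N[C@@H](CC(=O)O)C(=O)COc1c(F)cc(F)cc1F` carries the next change: 2,4,6-trifluorophenyl in place of naphthalen-1-yl on an oxygen on a saturated carbon. Like compound 2 and compound 3, compound 4 keeps an aryl ether at this position, and both of those ethers lie at the limit, so no readable step guides the prediction. Compound 4 is therefore expected to land around 120000 nM, between 30000 nM and 400000 nM, most likely as a limit again. That estimate means an expected step that the limit leaves unreadable from compound 2 to compound 4.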

Compound 4, half-maximal inhibitory concentration: 6840 nM
Compound 4: the middle estimate sits 18-fold (1.24 log units) above what was measured; measured number below the stated range.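

The change gives an at least 14-fold lower number from compound 2 to compound 4 (1.16 log units; beyond the scatter), and replacing 4-cyanophenyl gives an at least 14-fold lower number from compound 3 to compound 4 (1.16 log units; beyond the scatter), so an aryl ether on this oxygen does not by itself abolish inhibition, as the two earlier ethers alone had suggested. Replacing the (2,6-dichlorophenyl)carbonyl group gives a 1.5-fold lower number from compound 1 to compound 4 (0.19 log units; within the scatter), so this ether and that group cannot be told apart here. The choice of aryl group therefore decides the outcome, and a single ring alone is not enough, since the 4-cyanophenyl of compound 3 is one ring too.

From the compounds shown here alone, the true size of the two large steps stays open, as compound 2 and compound 3 are only limits: the limit of > 100000 nM in this assay, at which 2 of the 4 values shown sit. Also open, going by these compounds, is whether all three fluorine atoms matter, a question that a 4-fluorophenyl or a 2,4,6-trichlorophenyl ether at this position would address.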